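A Second Nitro Group Enters: What Compound 4 Might Show

A few compounds are considered here, and "the series" means these few. Any claim that something is new, unique, unknown or untested is made for them only; others in the source may bear on it.

Compound 1, `COc1ccc(C2CC(=NOC(=O)c3ccc(F)cc3)CC(c3ccc(OC)cc3)N2C)cc1`: 152000 nM in a functional assay, with a stated time of 30 min; a higher number here means a weaker inhibitor, a lower number a stronger inhibitor
Compound 2, `COc1ccc(C2CC(=NOC(=O)c3ccc(Cl)cc3)CC(c3ccc(OC)cc3)N2C)cc1`: 135000 nM
Compound 3, `COc1ccc(C2CC(=NOC(=O)c3ccc([N+](=O)[O-])cc3)CC(c3ccc(OC)cc3)N2C)cc1`: 280000 nM

The three measured compounds share one core and differ only in the aryl group on the carbonyl carbon. Compound 3 gives the highest of the three numbers. The step of a 1.8-fold higher number from compound 1 to compound 3 (0.27 log units; within the scatter) stays within the scatter, while the step of a 2.1-fold higher number from compound 2 to compound 3 (0.32 log units; beyond the scatter) is modest but beyond it; compound 1 and compound 2 themselves differ by a 1.1-fold lower number from compound 1 to compound 2 (0.05 log units; within the scatter).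

Compound 4, `COc1ccc(C2CC(=NOC(=O)c3cc([N+](=O)[O-])cc([N+](=O)[O-])c3)CC(c3ccc(OC)cc3)N2C)cc1`, has not yet been measured. Its change from compound 3 is 3,5-dinitrophenyl in place of 4-nitrophenyl on a carbonyl carbon. Within the data shown here, the only steps that bear on it are the two that bring a nitro group onto that ring, and both were small, so nothing measured here shows what a second nitro group does. A further small rise in the number, or no step beyond the scatter, is the reasonable expectation. Compound 4 is therefore estimated at 350000 nM, with a range from 150000 nM to 800000 nM, which would mean an expected step of a 1.3-fold higher number from compound 3 to compound 4 (0.10 log units; within the scatter).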

Compound 4, half-maximal inhibitory concentration: 312000 nM
Compound 4: middle estimate off by 1.1-fold (0.05 log units), on the high side; measured number inside the range.
By their numbers in this assay, from the lowest: compounds 2, 1, 3 and 4 (each within the scatter of the next, the first and the last beyond it).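

In this assay the second nitro group leaves the number within the scatter, with a 1.1-fold higher number from compound 3 to compound 4 (0.05 log units; within the scatter) as its step, so 3,5-dinitrophenyl and 4-nitrophenyl on the carbonyl carbon cannot be told apart here. Set against the two halogen-bearing rings, 3,5-dinitrophenyl lies beyond the scatter on both counts, with a 2.3-fold higher number from compound 2 to compound 4 (0.36 log units; beyond the scatter) and a 2.1-fold higher number from compound 1 to compound 4 (0.31 log units; beyond the scatter) as modest steps, whereas compound 3 passed that line only against compound 2. No measurement at hand explains these small steps.

On these data alone, all four compounds carry a substituted phenyl ring at this position and give numbers close together, so it stays open whether any change here can lower the number substantially. An amine or a carboxylic acid on that ring, or a simple alkyl chain in place of the ring, would test this.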